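Aryl in Place of Methyl on the Amide Nitrogen

A few compounds are considered here, and "the series" means these few. Any claim that something is new, unique, unknown or untested is made for them only; others in the source may bear on it.

Compound 1 `CNC(=O)c1c(O)c2cccnc2n(-c2ccccc2)c1=O` is the reference point of this small set. Among the measured compounds shown here, in a functional assay on the whole organism for inhibition, with Rattus norvegicus as the target, read by cytopathic effect and paw edema, at a dose of 100 mg/kg by the oral route (on this read-out lower numbers stand for less inhibition and higher numbers for more inhibition at the one dose given (going by the name of the read-out)), compound 1 gives 21%, the highest of the three numbers known, and both other compounds lie beyond the scatter below it. Compound 2 `O=C(Nc1ccccc1)c1c(O)c2cccnc2n(-c2ccccc2)c1=O` gives -15% in this assay, and compound 3 `O=C(Nc1ccc(Cl)cc1)c1c(O)c2cccnc2n(-c2ccccc2)c1=O` gives 2.5%. Between those two the step is a number 17.5 percentage points higher from compound 2 to compound 3 (beyond the scatter), which goes with chloro in place of hydrogen on an aromatic carbon.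

Compound 4 `O=C(Nc1ccncc1)c1c(O)c2cccnc2n(-c2ccccc2)c1=O` has not yet been measured. Its difference from compound 1 is pyridin-4-yl in place of methyl on an amide-type nitrogen. For the measured compounds named here, two measured steps bear on this directly, since each also puts a six-membered aromatic ring in place of the methyl on the amide-type nitrogen: a number 36 percentage points lower from compound 1 to compound 2 (beyond the scatter) and a number 18.5 percentage points lower from compound 1 to compound 3 (beyond the scatter). Both run downward, one large and one modest. Pyridin-4-yl itself has no precedent among the measured compounds, so the size of the step cannot be pinned more closely than by noting that an aromatic ring in this place has twice lowered the number. A downward step beyond the scatter is therefore expected, of about a number 21 percentage points lower from compound 1 to compound 4 (beyond the scatter). Compound 4 is estimated to give 0% in this assay, within a range from -20% to 20%.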

Compound 4, a percentage reported as inhibition, in the whole organism at one dose (the size of the read-out at that dose, not a potency): 24.3%
Beside the measured number, compound 4's estimate is 24.3 percentage points below it, and the stated range ends below it.
By their numbers in this assay, from the lowest: compound 2; then compound 3; then compounds 1 and 4 (each within the scatter of the next).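

Compounds 2 and 3 had suggested that any aromatic ring on the amide-type nitrogen lowers the number, but in this assay pyridin-4-yl in place of methyl gives a number 3.3 percentage points higher from compound 1 to compound 4 (within the scatter) and so breaks that reading. The ring placed on this nitrogen therefore matters more than the presence of a ring as such: pyridin-4-yl in place of phenyl gives a number 39.3 percentage points higher from compound 2 to compound 4 (beyond the scatter) as a large step, and pyridin-4-yl in place of 4-chlorophenyl gives a number 21.8 percentage points higher from compound 3 to compound 4 (beyond the scatter) as a modest one, so among the three aromatic groups only pyridin-4-yl stays level with methyl. Nothing at hand explains why these steps take the size they do.

The compounds shown leave open whether pyridin-2-yl or pyridin-3-yl on the same nitrogen would match pyridin-4-yl, and whether an amine or a carboxylic acid on that ring would shift the number. They also leave open how a longer chain, such as ethyl or butyl, would compare with methyl, and how any of these compounds would read at another dose.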